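What one flipped stereocentre might do

The source may hold more compounds than are shown below. What is called first, only, known or untested is meant among the compounds shown, and "the series" means these compounds.

In an ADME assay on the whole organism for inhibition, with Echinochloa crus-galli var. formosensis as the target, with a stated time of 4 days (on this read-out higher numbers stand for weaker inhibition and lower numbers for stronger inhibition), compound 1 `CCCCNc1nc(Cl)nc(N[C@H](C)c2ccccc2)n1` gives 38900 nM and compound 2 `CCCNc1nc(Cl)nc(N[C@H](C)c2ccccc2)n1` gives 33100 nM while compound 3 `CC[C@H](C)Nc1nc(Cl)nc(N[C@@H](C)c2ccccc2)n1` has the lowest number of the three at 14100 nM on this scale. Compound 4 `CC[C@H](C)Nc1nc(Cl)nc(N[C@H](C)c2ccccc2)n1` differs from compound 3 in configuration only: the two compounds have the same atoms and bonds and differ only in configuration as drawn: 1 of 2 stereo elements differ; a stereocentre at a saturated chain carbon is drawn S in compound 3 and R in compound 4 with a stereocentre at a saturated chain carbon drawn S in compound 3 and R in compound 4. For the measured compounds named here, no measured step changes a stereocentre. The only one available is a 1.2-fold lower number from compound 1 to compound 2 (0.07 log units; within the scatter) and it shortens a chain, so it offers little guidance. Compound 1 and compound 2 already carry the configuration that compound 4 gains at that centre, and both numbers sit higher than that of compound 3. A modest rise that stays within the scatter is therefore expected, with a 1.6-fold higher number from compound 3 to compound 4 (0.19 log units; within the scatter) as the estimated step. Compound 4 is estimated at 22000 nM with 8000 nM to 55000 nM as its range.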

Compound 4, half-maximal inhibitory concentration: 52500 nM
Estimate against measurement, compound 4: 2.4-fold (0.38 log units) below; the range from low to high includes it.
By their numbers in this assay, from the lowest: compound 3; then compounds 2, 1 and 4 (each within the scatter of the next).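

In this assay, for the compounds shown here, changing nothing but the configuration at one saturated chain carbon gives a 3.7-fold higher number from compound 3 to compound 4 (0.57 log units; beyond the scatter), so this stereocentre matters, which no earlier step could show: the fact that compounds 3 and 4 differ only in the configuration as drawn. With that centre as drawn in compound 4, changing the other chain makes little difference, with a 1.6-fold higher number from compound 2 to compound 4 (0.20 log units; within the scatter) and a 1.3-fold higher number from compound 1 to compound 4 (0.13 log units; within the scatter).

Going by these compounds, whether the second stereocentre, in the sec-butyl group, matters as much remains open. So does whether the same flip would have a similar effect with a pentyl chain or a cyclopropyl group in place of sec-butyl.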